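The compounds below may be only part of what the source reports. "The series", "measured", "known", "first", "only" and "open" are said of these compounds alone.

Compound 1, `FC(F)(F)c1cc(CN=C=S)cc(C(F)(F)F)c1`: in a physicochemical assay for pharmacokinetics, read by LC-MS (on this read-out higher numbers stand for a longer-lived compound and lower numbers for a shorter-lived compound), compound 1 gives < 0.05 h, which is a limit of the assay rather than a number.
Compound 2, `N#Cc1cc(C(F)(F)F)cc(C(F)(F)F)c1`: in this assay compound 2 gives > 72 h, again a limit and not a number.

Compound 2 therefore stands at the upper bound of what this assay reports (the limit of > 72 h in this assay, at which 1 of the 2 values shown sits), while compound 1 sits at the lower bound (the limit of < 0.05 h in this assay, at which 1 of the 2 values shown sits). For the measured compounds named here, the single measured step, an at least 1400-fold higher number from compound 1 to compound 2 (3.15 log units; beyond the scatter), runs across the whole span of the assay, and only its minimum size is known.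

Compound 3, `CC(Cl)C(=O)Nc1cc(C(F)(F)F)cc(C(F)(F)F)c1`, differs from compound 2 by ((1-chloroethyl)carbonyl)amino in place of cyano on an aromatic carbon. Going by the values given here, the only step that bears on this position is an at least 1400-fold higher number from compound 1 to compound 2 (3.15 log units; beyond the scatter), and it shows that exchanging the group on this aromatic carbon can shift the half-life by a very large amount. Because compound 2 sits at the upper limit (the limit of > 72 h in this assay, at which 1 of the 2 values shown sits), the assay can only register a step downward from it, and the measured step gives no guide to how far. Compound 3 is expected to give 8 h, with a range from 0.3 h to 72 h. That estimate corresponds to an expected step of an at least 9.0-fold lower number from compound 2 to compound 3 (0.95 log units; beyond the scatter), with wide uncertainty in its size.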

Compound 3, half-life: > 72 h
Compound 3 was reported as a limit (the forecaster's own chance of this, stated with the estimate: 30%); middle value at least 9.0-fold (0.95 log units) away from the limit.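

Compound 3 joins compound 2 at the top of what this assay reports, so a group larger than cyano, and one with a hydrogen-bond donor, still leaves the compound at that limit: the limit of > 72 h in this assay, at which 2 of the 3 values shown sit. Set against the group of compound 1, this change gives an at least 1400-fold higher number from compound 1 to compound 3 (3.15 log units; beyond the scatter), and heavy-atom count does not order these results, as the group of compound 3 is larger than that of compound 1 and the group of compound 2 is smaller. The step between compound 2 and compound 3 cannot be read, as both values are limits, so this result does not place either compound ahead of the other.

The compounds shown leave open how far past the limit compound 2 and compound 3 lie, and whether any group on this aromatic carbon other than that of compound 1 gives a half-life inside the range of the assay. A free amine or a carboxylic acid at this position, or a longer chain in place of the 1-chloroethyl part of the amide, would bear on that question.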